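The source may report more compounds than this note shows. Statements on the series, on what has been measured and on what is new or still open speak of the compounds shown alone.

Compound 1 `CCOC(=O)CCCCCOc1cccc(CN(C(=O)c2ccccc2)C(C)C)c1` gives > 26000 nM in an ADME assay on HepG2 cells (Homo sapiens) for cytotoxicity, read by CellTiter-Glo and resazurin assay, with a stated time of 72 h (a higher number here means that more compound is needed for the effect, a lower number that less compound is needed), which is a limit of the assay rather than a number.
Compound 2 `CCOC(=O)CCCCCOc1cccc(CN(C(=O)c2ccc(-c3cccc(Oc4ccccc4)c3)cc2)C(C)C)c1` gives > 26000 nM in this assay, again a limit of the assay rather than a number.

Compound 2 therefore stands exactly where every measured value here stands, namely at the limit of > 26000 nM in this assay, at which 2 of the 2 values shown sit. For the measured compounds named here, neither measured compound produced a number, so nothing can be said about either beyond the fact that both sit at the same limit, and no step between them is available. Compound 3 `CCOC(=O)CCCCCOc1cccc(CN(C(=O)c2ccc(-c3cccc(-c4nnc(C)o4)c3)cc2)C(C)C)c1` has not yet been measured. It differs from compound 2 in one place: 5-methyl-1,3,4-oxadiazol-2-yl in place of phenoxy on an aromatic carbon. Going by the values given here, with no measured step to draw on, and with both measured values at the limit, the expectation for the new compound can rest only on that shared limit. Compound 3 is therefore expected to give 40000 nM in this assay, with a range from 20000 nM to 120000 nM, and most likely to be reported as a limit once more. For compound 3 this expectation amounts to a step that the limit leaves unreadable from compound 2 to compound 3, a step of no size beyond the usual scatter and in no particular direction.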

Compound 3, half-maximal effective concentration: > 26000 nM
Compound 3: only a limit was reported (the forecaster's own chance of this, stated with the estimate: 85%); the middle value does not contradict the limit.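

The steps from compound 1 to compound 3 and from compound 2 to compound 3 cannot be read, because compound 1, compound 2 and compound 3 all share one limit of the assay rather than a number: the limit of > 26000 nM in this assay, at which 3 of the 3 values shown sit. Still open is how much of any of these compounds produces the effect in this assay, and whether exchanging phenoxy for 5-methyl-1,3,4-oxadiazol-2-yl changes that amount.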